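The compounds below may be only part of what the source reports. "The series", "measured", "known", "first", "only" and "open" are said of these compounds alone.

Working notes on the series. Compound 1 `CCCCCCC#Cc1cn([C@@H]2O[C@H](CO)[C@@H](O)[C@H]2O)c(=O)[nH]c1=O` gives 15700 nM in an ADME assay on MRC5 cells (Homo sapiens) for cytotoxicity, read by MTT assay; a lower number here means that less compound is tolerated, a higher number that more compound is tolerated. Compound 2 `O=c1[nH]cc(C#CC(O)c2ccccc2)c(=O)[nH]1` gives 38400 nM in this assay. Compound 3 `O=c1[nH]c(=O)n([C@@H]2O[C@H](CO)[C@@H](O)[C@H]2O)cc1C#CC1CC1` gives 24200 nM in this assay, the second highest of the three numbers; compound 1 is its nearest neighbour and compound 2 its furthest, both within the scatter, so no order among the three can be read. Among the measured compounds shown here, the single step between measured compounds, a 1.5-fold higher number from compound 1 to compound 3 (0.19 log units; within the scatter), exchanged the group on the triple-bonded carbon and stayed within the scatter.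

Compound 4 `O=c1[nH]c(=O)n([C@@H]2O[C@H](CO)[C@@H](O)[C@H]2O)cc1C#CC(O)c1ccccc1` differs from compound 3 by hydroxy(phenyl)methyl in place of cyclopropyl on a triple-bonded carbon. The step from compound 1 to compound 3 is the only one that touches this position, and it shifted nothing beyond the scatter. Compound 2, which carries the same hydroxy(phenyl)methyl group on a triple-bonded carbon, gives 38400 nM in this assay, within the scatter of compound 3. No step beyond the scatter is therefore expected in this assay. Compound 4 is expected to give 28000 nM, with a range of 14000 nM to 56000 nM. The expected step is a 1.2-fold higher number from compound 3 to compound 4 (0.06 log units; within the scatter).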

Compound 4, half-maximal cytotoxic concentration: 900 nM
The estimate for compound 4 lay 31-fold (1.49 log units) above the measured number; the whole stated range lies above it.
By their numbers in this assay, from the lowest: compound 4; then compounds 1, 3 and 2 (each within the scatter of the next, the first and the last beyond it).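

In this assay the triple-bonded carbon now proves sensitive to the group it carries: with hydroxy(phenyl)methyl entering, a 27-fold lower number from compound 3 to compound 4 (1.43 log units; beyond the scatter) and a 17-fold lower number from compound 1 to compound 4 (1.24 log units; beyond the scatter) both lie beyond the scatter, whereas cyclopropyl in place of hexyl stayed within it. That group does not give a low number on its own: compound 2 carries it too, and a 43-fold lower number from compound 2 to compound 4 (1.63 log units; beyond the scatter) comes with 3,4-dihydroxy-5-(hydroxymethyl)oxolan-2-yl in place of hydrogen on an aromatic nitrogen, so the low number is seen only where both groups stand together, in compound 4. Nothing available on these compounds accounts for this drop.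

Which part of hydroxy(phenyl)methyl goes with the low number remains open, since the compounds shown do not separate its hydroxy from its aromatic ring. Going by these compounds, how a plain benzyl group or an amine on the triple-bonded carbon would read in this assay also remains open.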